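The compounds below may be only part of what the source reports. "The series", "measured", "known", "first", "only" and "open" are said of these compounds alone.

Measured compounds: compound 1, `COc1cc2cc(Oc3ccc(NC(=O)Nc4cccc(C(F)(F)F)c4)cc3)c(C)nc2cc1OC`, with 4950 nM in a functional assay on A498 cells (Homo sapiens) for inhibition, read by sulforhodamine B assay, with a stated time of 48 h; on this read-out lower numbers stand for stronger inhibition of growth and higher numbers for weaker inhibition of growth; compound 2, `COc1cc2cc(Oc3ccc(NC(=O)Nc4ccc(Cl)c(C(F)(F)F)c4)cc3)c(C)nc2cc1OC`, with 3320 nM in this assay.

In this assay compound 2 gives the lower of the two numbers, yet the step of a 1.5-fold lower number from compound 1 to compound 2 (0.17 log units; within the scatter) stays within the scatter, so neither compound can be set apart from the other. Compound 3, `COc1cc2cc(Oc3ccc(NC(=O)Nc4ccc(Cl)c(Cl)c4)cc3)c(C)nc2cc1OC`, differs from compound 2 by chloro in place of trifluoromethyl on an aromatic carbon. For the measured compounds named here, no measured step covers an exchange of this kind; the only step seen concerns a chloro replacing hydrogen, and it was small. Compound 3 is therefore expected to stay close to compound 2 in this assay, with an estimated 4000 nM (range 1500 nM to 10000 nM), a step of a 1.2-fold higher number from compound 2 to compound 3 (0.08 log units; within the scatter) that is expected to fall within the scatter.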

Compound 3, concentration for total growth inhibition: 7930 nM
Compound 3: middle estimate off by 2.0-fold (0.30 log units), on the low side; the range from low to high includes it.
By their numbers in this assay, from the lowest: compounds 2, 1 and 3 (each within the scatter of the next, the first and the last beyond it).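

In this assay, for the compounds shown here, trifluoromethyl giving way to chloro on this aromatic carbon, ortho to a chloro group, produces the first step that passes the scatter, a 2.4-fold higher number from compound 2 to compound 3 (0.38 log units; beyond the scatter), so this position does respond to the exchange. The step of a 1.6-fold higher number from compound 1 to compound 3 (0.20 log units; within the scatter) nevertheless stays within the scatter, which leaves the 3,4-dichlorophenyl and 3-(trifluoromethyl)phenyl groups not set apart. No evidence at hand accounts for either step. Going by these compounds, how a methoxy group, a nitrile or an amine at this position would read in this assay remains open.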